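The compounds below may be only part of what the source reports. "The series", "measured", "known", "first", "only" and "open" are said of these compounds alone.

Compound 3 `CCCCC(O)Cn1cc(CN(C)CCC(C)C)nn1` gives 47% in an assay on nucleic acid for inhibition of Nucleic Acid, read by fluorescence, tested at 100 uM (on this read-out lower numbers stand for less inhibition and higher numbers for more inhibition at the one concentration tested (going by the name of the read-out)), level with compound 1 `CCCCC(O)Cn1cc(CN(C)CC2CCCCC2)nn1` at the digits shown, which in this assay gives 47%; together these two are the highest of the three numbers. Compound 2 `CN(CCCc1ccccc1)Cc1cn(CC(O)COC(=O)c2ccccc2)nn1` stands furthest off, giving 12% in this assay, a number lower than compound 3 by more than the scatter, but compound 2 differs from compound 3 in more than one place, so its value cannot be tied to any single change. Going by the values given here, the only measured step that alters a single feature, no change at the digits printed from compound 1 to compound 3 (within the scatter), exchanges cyclohexyl for isobutyl on the saturated chain carbon bound to the amine nitrogen and leaves the read-out unchanged. Compound 4 `CCCCC(O)Cn1cc(CN(C)CCCc2ccccc2)nn1` arises from compound 3 by benzyl in place of isopropyl on a saturated chain carbon, two bonds along the chain from an amine nitrogen. The change sits on the same chain as the measured step, yet it introduces one six-membered aromatic ring of carbon only where that step kept to saturated groups, so it bears on compound 4 only loosely. The step is therefore expected to be small, a number 5 percentage points lower from compound 3 to compound 4 (within the scatter), with no direction claimed beyond the scatter. Compound 4 is estimated to give 42% in this assay, within a range from 20% to 60%.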

Compound 4, a percentage reported as inhibition, at one concentration (the size of the read-out at that concentration, not a potency): 37%
Estimate against measurement, compound 4: 5 percentage points above, and the stated range covers the measured number.
By their numbers in this assay, from the lowest: compound 2; then compounds 4, 1 and 3 (each within the scatter of the next).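

In this assay, benzyl in place of isopropyl on a saturated chain carbon, two bonds along the chain from an amine nitrogen, brings in one six-membered aromatic ring of carbon only, and the step is a number 10 percentage points lower from compound 3 to compound 4 (within the scatter) while exchanging the cyclohexyl group on the same chain gives a number 10 percentage points lower from compound 1 to compound 4 (within the scatter), so on the three compounds compared here this position takes an aromatic ring with no change beyond the scatter. Going by these compounds alone, the other side of the molecule now has a single-place comparison of its own, with propyl in place of benzoyloxy on a saturated chain carbon, two bonds along the chain from an oxygen on a saturated carbon, which gives a number 25 percentage points higher from compound 2 to compound 4 (beyond the scatter) and is the only new step beyond the scatter, so the low number of compound 2 can now be tied to that one change. Nothing given here explains either result.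

Going by these compounds, what a carboxylic acid or a primary amide would give in place of benzyl at this position stays open, as does the effect of a longer chain than phenethyl. Whether a phenyl group in place of propyl would bring the number back down toward that of compound 2 is open as well.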